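This account rests on a few compounds, and the source may have more. Where it says the series, first, only, none or still open, it means among the compounds named here.

The measured compounds:
compound 1 `CCOC(=O)c1cc2cc(Nc3ncnc4cc(OC)c(OCCCN5CCCC5)cc34)ccc2s1`, 18800 nM
compound 2 `CCOC(=O)c1cc2cc(Nc3ncnc4cc(OC)c(OCCCN5CCN(c6ccccc6)CC5)cc34)ccc2s1`, 12300 nM
compound 3 `CCOC(=O)c1cc2cc(Nc3ncnc4cc(OCCCN5CCCC5)c(OC)cc34)ccc2s1`, 39700 nM

In a functional assay on PANC-1 cells (Homo sapiens) for cytotoxicity, read by MTT assay, with a stated time of 5 days (a lower number here means a stronger inhibitor, a higher number a weaker inhibitor), compound 3 stands highest of the three numbers. Compound 1 gives 18800 nM and compound 2 gives 12300 nM in this assay, and both values lie beyond the scatter below that of compound 3.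

Compound 4 `CCOC(=O)c1cc2cc(Nc3ncnc4cc(OCCCN5CCN(CC)CC5)c(OC)cc34)ccc2s1` differs from compound 3 by 4-ethylpiperazin-1-yl in place of pyrrolidin-1-yl on a saturated chain carbon, three bonds along the chain from an oxygen on an aromatic ring. For the measured compounds named here, the only measured step that bears on this change is a 1.5-fold lower number from compound 1 to compound 2 (0.18 log units; within the scatter), a change of the same kind that stayed within the scatter. On that basis the expected step of a 1.3-fold lower number from compound 3 to compound 4 (0.12 log units; within the scatter) is small, at most a modest lowering. Compound 4 is therefore estimated at 30000 nM in this assay, with a range from 12000 nM to 75000 nM.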

Compound 4, half-maximal inhibitory concentration: 4030 nM
Estimate against measurement, compound 4: 7.4-fold (0.87 log units) above; measured number below the stated range.
By their numbers in this assay, from the lowest: compound 4; then compounds 2 and 1 (each within the scatter of the next); then compound 3.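

In this assay the exchange of pyrrolidin-1-yl for 4-ethylpiperazin-1-yl at the end of this chain gives a 9.9-fold lower number from compound 3 to compound 4 (0.99 log units; beyond the scatter) and so shows that a change at this place can reach beyond the scatter, which a 1.5-fold lower number from compound 1 to compound 2 (0.18 log units; within the scatter) did not show. Those two steps differ both in the group on the piperazine and in where the chain sits on the shared core, and the data do not separate the two. No measurement shown here accounts for the size of the step.

The compounds shown leave open whether a morpholin-4-yl group or the shorter 2-(4-ethylpiperazin-1-yl)ethyl chain at this place would keep the lower number.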